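Cyclohexyl for propyl on a thiourea sulfonamide

The source may hold more compounds than are shown below. What is called first, only, known or untested is meant among the compounds shown, and "the series" means these compounds.

Compound 2 `CCCNC(=S)NS(=O)(=O)c1ccc(-n2nc(C)cc2C)cc1` was tested in a functional assay on the whole organism (blood, strain albino) with Mus musculus as the target, with stated times of 6 days and 4 h, at a dose of 0.4 mmol/kg by the oral route; on this read-out higher numbers stand for more inhibition at the one dose given (going by the name of the read-out) and lower numbers for less inhibition. In this assay compound 2 reaches only the limit of the assay, < 1%, which is a limit and not a number (the limit of < 1% in this assay, at which 1 of the 3 values shown sits). Compound 1 `Cc1cc(C)n(-c2ccc(S(=O)(=O)NC(=O)NNC(=N)N)cc2)n1` gives 3% in this assay, and compound 3 `CCCCNC(=O)NS(=O)(=O)c1ccc(-n2nc(C)cc2C)cc1` gives 2%. The steps of a number at least 2 percentage points lower from compound 1 to compound 2 (that floor lies within the scatter) and a number 1 percentage points lower from compound 1 to compound 3 (within the scatter) lie within the scatter, as does a number at least 1 percentage points higher from compound 2 to compound 3 (that floor lies within the scatter). Compound 4 `Cc1cc(C)n(-c2ccc(S(=O)(=O)NC(=S)NC3CCCCC3)cc2)n1` is not yet measured; it differs from compound 2 by cyclohexyl in place of propyl on an amide-type nitrogen. The nearest measured comparison, also a change on an amide-type nitrogen, is a number 1 percentage points lower from compound 1 to compound 3 (within the scatter), which stayed within the scatter. The account therefore expects for compound 4 no step beyond the scatter, a number at least 1 percentage points higher from compound 2 to compound 4 (that floor lies within the scatter). The estimate for compound 4 in this assay is 2%, ranging from 0% to 10%.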

Compound 4, a percentage reported as inhibition, in the whole organism at one dose (the size of the read-out at that dose, not a potency): < 2%
Compound 4: a limit, no number; the forecaster's own chance of this, stated with the estimate: 40%; the middle value sits exactly at the limit.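

Among these compounds, compound 2 and compound 4 each give a limit and not a number, so no step between them can be read. The compounds shown leave open whether cyclohexyl in place of propyl changes inhibition at all.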